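The source may hold more compounds than are shown below. What is called first, only, known or untested is meant among the compounds shown, and "the series" means these compounds.

Going by the values given here, in a functional assay on HT-29 cells (Homo sapiens) for antiproliferative activity, with a stated time of 72 h (on this read-out higher numbers stand for weaker inhibition and lower numbers for stronger inhibition), compound 1 (`COc1ccc(-n2ccc3c(OC)c(OC)c(OC)cc32)cc1`) gives 179 nM, the lower of the two numbers so far, and compound 2 (`COc1ccc(-n2ccc3c(OC)c(OC)c(OC)cc32)cc1O`) gives 6400 nM. Compound 3 (`COc1cc2c(ccn2-c2ccc(N(C)C)cc2)c(OC)c1OC`) differs from compound 1 by dimethylamino in place of methoxy on an aromatic carbon, para to a large group. Among the compounds with values here, only one measured step is available, a 36-fold higher number from compound 1 to compound 2 (1.55 log units; beyond the scatter), and it is a different change, hydroxy in place of hydrogen on an aromatic carbon. It bears on compound 3 only indirectly, showing that one small substitution on the core of compound 1 can move this assay by a large amount. Within the data shown here, no measured step replaces the methoxy group, so the data do not fix a direction. A moderate loss is expected, smaller than the step to compound 2, with a wide margin. The expected change is a 1.7-fold higher number from compound 1 to compound 3 (0.22 log units; within the scatter). For compound 3 the estimated value is 300 nM, with an expected range from 70 nM to 1500 nM.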

Compound 3, half-maximal inhibitory concentration: 148 nM
The estimate for compound 3 lay 2.0-fold (0.31 log units) above the measured number; the measured number falls inside the stated range.
By their numbers in this assay, from the lowest: compounds 3 and 1 (each within the scatter of the next); then compound 2.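

Going by these compounds alone, replacing methoxy with dimethylamino on an aromatic carbon, para to a large group, gives in this assay a 1.2-fold lower number from compound 1 to compound 3 (0.08 log units; within the scatter) and is the first step that does not separate two compounds on this read-out. One larger group can therefore stand at this place on the shared core without a shift beyond the scatter, whereas the hydroxy step, a 36-fold higher number from compound 1 to compound 2 (1.55 log units; beyond the scatter), is a large one. Nothing measured on these compounds accounts for either outcome.

The compounds shown leave open whether this place accepts groups of other kinds, such as a primary amine, a carboxylic acid or a longer alkoxy chain. They also leave open whether compound 1 and compound 3 stay this close in other cell lines.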